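From 2-methoxybenzyl to 4-cyanobenzyl: a step among limits

The source may report more compounds than this note shows. Statements on the series, on what has been measured and on what is new or still open speak of the compounds shown alone.

Measured in a physicochemical assay for solubility, using the shake flask method, in simulated intestinal fluid, measured as kinetic solubility, with a stated time of 2 h, at 25 degrees C, at pH 6.5 (on this read-out lower numbers stand for lower solubility and higher numbers for higher solubility), each value a limit and not a number:
- compound 1 (`Cc1noc(-c2nc(C)c3c(c2N)C(=O)N(Cc2ccccc2)C3=O)n1`) gives < 5000 nM
- compound 2 (`COc1ccc(CN2C(=O)c3c(C)nc(-c4nc(C)no4)c(N)c3C2=O)cc1`) gives < 5000 nM
- compound 3 (`COc1ccccc1CN1C(=O)c2c(C)nc(-c3nc(C)no3)c(N)c2C1=O`) gives < 5000 nM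

Compound 3 stands at a limit (< 5000 nM) and not at a number. Across the measured compounds the picture is the limit of < 5000 nM in this assay, at which 3 of the 3 values shown sit, so compound 3 has no rank among them.

Compound 4 (`Cc1noc(-c2nc(C)c3c(c2N)C(=O)N(Cc2ccc(C#N)cc2)C3=O)n1`) has not yet been measured. It carries 4-cyanophenyl in place of the 2-methoxyphenyl of compound 3, on a saturated chain carbon bound to an amide-type nitrogen in a ring (4-cyanophenyl in place of 2-methoxyphenyl on a saturated chain carbon bound to an amide-type nitrogen in a ring).

The measured steps nearest this change are a step that the two limits leave unreadable from compound 2 to compound 3 and a step that the two limits leave unreadable from compound 1 to compound 3, and a step that the two limits leave unreadable from compound 1 to compound 2 is no more informative. None of them offers a size to carry over, so no shift beyond the usual scatter is expected in this assay, in either direction. The expected step is a step that the limit leaves unreadable from compound 3 to compound 4, and this is only an estimate. Compound 4 is estimated at 3000 nM (expected range 800 nM to 8000 nM).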

Compound 4, solubility: < 5000 nM
Compound 4: only a limit was reported; the forecaster's own chance of this, stated with the estimate: 85%; the middle value lies beyond the limit too.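

In this assay compound 4 gives only a limit, < 5000 nM, so no step from compound 1, compound 2 or compound 3 to it can be read, and the whole set sits at such a limit: the limit of < 5000 nM in this assay, at which 4 of the 4 values shown sit.

The compounds shown leave open whether these four differ in solubility at all, and by how much.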